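A few compounds are considered here, and "the series" means these few. Any claim that something is new, unique, unknown or untested is made for them only; others in the source may bear on it.

Measured compounds in a functional assay on the whole organism (strain albino) for inhibition, with Rattus norvegicus as the target, read by paw edema, with stated times of 30 min and 2 h, at a dose of 5 mg/kg by the oral route; a lower number here means less inhibition, a higher number more inhibition at the dose given (going by the name of the read-out):
Compound 1, `CCOC(=O)Cc1nc(N)n(C(=O)c2ccccc2)n1`, gives 38.5%.
Compound 2, `CCOC(=O)Cc1nc(N)n(C(=O)c2ccc(Cl)cc2)n1`, gives 42.3%.
Compound 3, `CCOC(=O)Cc1n[nH]c(NC(=O)c2ccccc2)n1`, gives 36.2%.

Within the data shown here, compounds 1 and 2 share a core; the one change between them is chloro in place of hydrogen on an aromatic carbon, and the step it made in this assay is a number 3.8 percentage points higher from compound 1 to compound 2 (within the scatter). Compound 3 has the same atoms as compound 1 joined differently, so it carries another core; the difference between the two cores is not broken down here. Compound 3 stands near compound 1, with its value in this assay a little lower, yet the gap between them is within the scatter, so no order between the two can be read from these numbers.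

Compound 4, `CCOC(=O)Cc1n[nH]c(NC(=O)c2ccc(Cl)cc2)n1`, has not yet been measured in this assay. Among the measured compounds shown here, it differs from compound 3 by chloro in place of hydrogen on an aromatic carbon, the same kind of change as the one that led from compound 1 to compound 2, made on the core of compound 3 rather than on the core of compound 1. Since the step from compound 1 to compound 2 stayed within the scatter, the step from compound 3 to compound 4 is expected to be about as small, near a number 3.8 percentage points higher from compound 3 to compound 4 (within the scatter). The value of compound 4 in this assay is therefore estimated at 40%, most likely between 30% and 50%.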

Compound 4, a percentage reported as inhibition, in the whole organism at one dose (the size of the read-out at that dose, not a potency): 39.1%
Compound 4: middle estimate off by 0.9 percentage points, on the high side, and the stated range covers the measured number.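

Putting chloro in place of hydrogen on an aromatic carbon of the core of compound 3 gave a number 2.9 percentage points higher from compound 3 to compound 4 (within the scatter) in this assay. Set beside the earlier step, the same change gave closely matching results on the two cores: the same change on two cores in this assay, a number 3.8 percentage points higher (within the scatter) from compound 1 to compound 2 and a number 2.9 percentage points higher (within the scatter) from compound 3 to compound 4, 0.9 percentage points apart, within the scatter of two such steps. Among these compounds, this shows that, on these two cores, the change carried over with no difference between the steps that stands out from the scatter, but it does not show that chloro raises the inhibition on either core, since each step is itself within the scatter, and two cores read at one dose say nothing about how the change would behave on any other core.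

The compounds shown carry only hydrogen or chloro at this place on the aromatic ring, so what a fluoro group, a methoxy group, a nitro group or an amine would give there remains open. The ethyl ester side chain is also the same in all of them, which leaves open what a carboxylic acid or a longer chain in its place would give in this assay.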